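Ethoxy in Place of 2-Methylphenyl on the Shared Core

The compounds below may be only part of what the source reports. "The series", "measured", "known", "first", "only" and "open" are said of these compounds alone.

Measured so far in a functional assay on A549 cells (Homo sapiens) for inhibition, read by MTT assay, with a stated time of 72 h; on this read-out higher numbers stand for weaker inhibition and lower numbers for stronger inhibition:
- compound 1 `Cc1ccc(-c2cc(C(=O)N3CCC4(CC3)CC(=O)c3nn(C(C)(C)C)cc3O4)c3ccccc3n2)cc1` gives 5300 nM
- compound 2 `Cc1ccccc1-c1cc(C(=O)N2CCC3(CC2)CC(=O)c2nn(C(C)(C)C)cc2O3)c2ccccc2n1` gives 1880 nM
- compound 3 `CC(C)(C)n1cc2c(n1)C(=O)CC1(CCN(C(=O)c3cc(-c4ccccc4Cl)nc4ccccc34)CC1)O2` gives 2180 nM

Compound 2 holds the lowest of the three numbers in this assay, but its standing is shared in practice: the step of a 1.2-fold higher number from compound 2 to compound 3 (0.06 log units; within the scatter) is within the scatter, so compound 2 and compound 3 cannot be ordered. Only against compound 1 is the difference real, a 2.8-fold lower number from compound 1 to compound 2 (0.45 log units; beyond the scatter), and likewise a 2.4-fold lower number from compound 1 to compound 3 (0.39 log units; beyond the scatter).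

Compound 4 `CCOc1cc(C(=O)N2CCC3(CC2)CC(=O)c2nn(C(C)(C)C)cc2O3)c2ccccc2n1` differs from compound 2 as follows: ethoxy in place of 2-methylphenyl on an aromatic carbon. Within the data shown here, every measured step so far exchanges one six-membered aromatic ring of carbon only for another, or one substituent on such a ring for another. None removes the ring and puts a short chain in its place. The measured steps therefore give no direct guide to this change, and what they do show is that shifts among the aryl variants were modest at most.

Among the measured compounds shown here, with no comparable step measured, the expectation is for a modest move toward a higher number in this assay, a 3.2-fold higher number from compound 2 to compound 4 (0.50 log units; beyond the scatter), with a wide range to reflect the absence of a precedent. Compound 4 is expected to give 6000 nM, within 1500 nM to 25000 nM.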

Compound 4, half-maximal inhibitory concentration: > 10000 nM
Compound 4: only a limit was reported; the forecaster's own chance of this, stated with the estimate: 15%; at least 1.6-fold (0.22 log units) between middle value and limit.
By their numbers in this assay, from the lowest: compounds 2 and 3 (each within the scatter of the next); then compound 1. At a limit, above all of these: compound 4.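

In this assay compound 4 gives > 10000 nM as a limit and not a number. Among these compounds, this is the first change at this carbon, next to the ring nitrogen, that removes the six-membered aromatic ring and leaves a short chain, and it moves the number further than any exchange among the aryl variants: the step of an at least 5.3-fold higher number from compound 2 to compound 4 (0.72 log units; beyond the scatter) and the step of an at least 4.5-fold higher number from compound 3 to compound 4 (0.66 log units; beyond the scatter) both lie beyond the scatter, and both are floors with no upper bound. The comparison with the third aryl variant is less firm, as the step of an at least 1.8-fold higher number from compound 1 to compound 4 (0.27 log units; that floor lies within the scatter) has a floor within the scatter, so the limit alone does not separate these two compounds.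

The compounds shown do not tell whether the number follows the loss of the aromatic ring itself or the smaller group, as ethoxy differs from 2-methylphenyl in both respects. A longer chain such as butoxy, an amine such as dimethylamino or a saturated ring such as cyclohexyl on the same carbon would pull these two readings apart.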